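This account rests on a few compounds, and the source may have more. Where it says the series, first, only, none or still open, it means among the compounds named here.

Working notes on the series.

The shared core of compound 1 `COc1ccc(CN2CCN(c3nc(Nc4ccc(C#N)c(C(F)(F)F)c4)nc(Oc4ccnc5ccccc45)n3)CC2)c(OC)c1OC` carries a piperazine whose chain carbon bears the 2,3,4-trimethoxyphenyl group. In a functional assay on DU-145 cells (Homo sapiens) for cytotoxicity, read by sulforhodamine B assay, with a stated time of 48 h (a lower number here means a stronger inhibitor of growth, a higher number a weaker inhibitor of growth), compound 1 gives > 100000 nM, which is a limit of the assay and not a number. Among the measured compounds shown here, compound 1 therefore stands at the limit of > 100000 nM in this assay, at which 1 of the 2 values shown sits, and no step from it to another compound can be sized. Compound 2 `N#Cc1ccc(Nc2nc(Oc3ccnc4ccccc34)nc(N3CCN(c4ncccn4)CC3)n2)cc1C(F)(F)F` replaces the whole benzyl arm by a pyrimidine on the ring nitrogen; in this assay compound 2 gives 85200 nM, so both measured compounds are weak inhibitors of growth, and the two values say nothing beyond that.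

Compound 3 `N#Cc1ccc(Nc2nc(Oc3ccnc4ccccc34)nc(N3CCN(Cc4ccccc4)CC3)n2)cc1C(F)(F)F` follows from compound 1 by the change (phenyl in place of 2,3,4-trimethoxyphenyl on a saturated chain carbon bound to an amine nitrogen in a ring). For the measured compounds named here, no measured step of this kind exists here. With compound 2 at 85200 nM, the expectation for compound 3 is a weak inhibitor, with at most a small gain in potency that may not exceed the usual scatter. The expected step is an at least 1.6-fold lower number from compound 1 to compound 3 (0.22 log units; that floor lies within the scatter). In this assay compound 3 is estimated at 60000 nM, within a range from 15000 nM to 200000 nM.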

Compound 3, concentration for 50% growth inhibition: > 100000 nM
Compound 3: a limit, no number; the forecaster's own chance of this, stated with the estimate: 35%; at least 1.6-fold (0.22 log units) between middle value and limit.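

Leaving out the three methoxy groups, with phenyl in place of 2,3,4-trimethoxyphenyl on a saturated chain carbon bound to an amine nitrogen in a ring, does not bring the series off the limit of this assay, and the step between these two limits cannot be read. With benzyl in place of pyrimidin-2-yl on an amine nitrogen in a ring, the values give an at least 1.1-fold higher number from compound 2 to compound 3 (0.06 log units; that floor lies within the scatter), so the data set no order between these two arms. The limit, which is not a number, now marks most of the series: the limit of > 100000 nM in this assay, at which 2 of the 3 values shown sit.

Still open, as far as these compounds go, is whether a longer chain in place of the benzyl arm, or a carboxylic acid or an amine on its phenyl ring, would give a value clear of the limit in this assay. All the compounds shown share one core, and what a carboxamide in place of its nitrile would do to growth inhibition also remains open.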